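Cytotoxicity notes on the benzyl-substituted sulfamide series

The source may hold more compounds than are shown below. What is called first, only, known or untested is meant among the compounds shown, and "the series" means these compounds.

Measured so far:
- compound 1 `O=C1c2ccccc2N(Cc2ccccc2)S(=O)(=O)N1Cc1ccccc1`, in a functional assay on HEL cells (Homo sapiens) (on this read-out higher numbers stand for lower toxicity in this test and lower numbers for higher toxicity in this test), compound 1 gives > 50000 nM
- compound 2 `O=C1c2ccccc2N(Cc2cccc(Cl)c2)S(=O)(=O)N1Cc1ccccc1`, in this assay compound 2 gives > 5000 nM
- compound 3 `O=C1c2ccccc2N(Cc2ccc(Cl)cc2)S(=O)(=O)N1Cc1ccc(Cl)cc1`, in this assay compound 3 gives > 50000 nM

All three values are limits of this assay, not numbers. Compound 3 sits at the limit of > 50000 nM in this assay, at which 2 of the 3 values shown sit, the same limit that compound 1 reaches. Among the compounds with values here, compound 2 sits at the limit of > 5000 nM in this assay, at which 1 of the 3 values shown sits, which is the only other value shown and is a limit as well. Within the data shown here, the single step between measured compounds, a step that the two limits leave unreadable from compound 1 to compound 2, therefore cannot be read, since both ends are limits of different depth.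

Compound 4 `O=C1c2ccccc2N(Cc2ccc(Cl)cc2)S(=O)(=O)N1Cc1ccccc1` differs from compound 3 by hydrogen in place of chloro on an aromatic carbon. Among the measured compounds shown here, no measured step speaks directly to this change, and the one step available is unreadable, so no step beyond the scatter can be predicted in this assay in either direction. Given that compound 3 stands at the limit of > 50000 nM in this assay, at which 2 of the 3 values shown sit, and compound 1 stands at the same limit, compound 4 is expected to remain at that limit, and the step of a number no higher from compound 3 to compound 4 (the limit leaves the size open) is estimated to be none beyond the scatter. The expected value for compound 4 in this assay is 50000 nM, with a range from 20000 nM to 100000 nM.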

Compound 4, minimum cytotoxic concentration: > 5000 nM
Compound 4: a limit, no number (the forecaster's own chance of this, stated with the estimate: 85%); the middle value does not contradict the limit.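

In this assay compound 4 gives > 5000 nM, a limit and not a number. Every value shown is a limit, so the steps to compound 4 from compound 1, compound 2 and compound 3 cannot be read. The compounds shown leave open the actual minimum cytotoxic concentration of each compound and whether chloro on a benzyl group changes it.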